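Compound 3: 1-aminocyclopentyl on the carbonyl carbon

The source may report more compounds than this note shows. Statements on the series, on what has been measured and on what is new or still open speak of the compounds shown alone.

In a functional assay on U-87MG ATCC cells (Homo sapiens) for antiproliferative activity (on this read-out higher numbers stand for weaker inhibition and lower numbers for stronger inhibition), compound 1 (`CC(=O)N1CCc2c(C)c3c(n2-c2ccc(C(N)=O)c(c2)N[C@@H](C)[C@H](C)C1)CC(C)(C)CC3=O`) gives 24 nM and compound 2 (`Cc1c2c(n3c1CCN(C(=O)C(C)(C)N)C[C@@H](C)[C@H](C)Nc1cc-3ccc1C(N)=O)CC(C)(C)CC2=O`) gives 39 nM, so these two values lie within the usual scatter of each other. Compound 3 (`Cc1c2c(n3c1CCN(C(=O)C1(N)CCCC1)C[C@@H](C)[C@H](C)Nc1cc-3ccc1C(N)=O)CC(C)(C)CC2=O`) keeps the core of compound 2 and differs in one group: 1-aminocyclopentyl in place of 1-amino-1-methylethyl on a carbonyl carbon. Among the measured compounds shown here, the only measured step at this place is a 1.6-fold higher number from compound 1 to compound 2 (0.21 log units; within the scatter), with 1-amino-1-methylethyl in place of methyl, and it stays within the scatter. On the evidence of that single step, no change beyond the scatter is expected in this assay. The expected step is a 1.0-fold higher number from compound 2 to compound 3 (0.01 log units; within the scatter). One step is thin evidence, so the range is kept wide. For compound 3 the estimated value is 40 nM, with an expected range from 15 nM to 105 nM.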

Compound 3, half-maximal inhibitory concentration: 44 nM
For compound 3 the middle estimate is 1.1-fold (0.04 log units) below the measured one; measured number inside the range.
By their numbers in this assay, from the lowest: compounds 1, 2 and 3 (each within the scatter of the next).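

Putting 1-aminocyclopentyl in place of 1-amino-1-methylethyl on the carbonyl carbon gives a 1.1-fold higher number from compound 2 to compound 3 (0.05 log units; within the scatter), so this assay does not separate these two groups, even though the new one is larger and brings a five-membered ring of carbon. The comparison with the small methyl group gives a 1.8-fold higher number from compound 1 to compound 3 (0.26 log units; within the scatter), so all three groups tried at this place, from methyl to 1-aminocyclopentyl, stay within the scatter of one another. No measurement is available that could explain this flat result.

On these data alone, it remains open whether a 1-aminocyclohexyl group, a cyclopentyl group without the amine or a carboxylic acid on this carbonyl carbon would also stay within the scatter. As far as these compounds go, it is also open whether these groups would stay this close in any other read-out.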